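This account rests on a few compounds, and the source may have more. Where it says the series, first, only, none or still open, it means among the compounds named here.

For the measured compounds named here, in an assay on isolated protein for inhibition of proto-oncogene tyrosine-protein kinase receptor Ret (Homo sapiens), read by 33P incorporation, with stated times of 15 min and 40 min (a higher number here means a weaker inhibitor, a lower number a stronger inhibitor), compound 3 `O=C(Nc1ccc(Br)cc1)Nc1ccc(Nc2ncnc3c2OCCN3)cc1` gives 2220 nM, the second highest of the three numbers known so far: compound 2 `O=C(Nc1ccc(Cl)cc1)Nc1ccc(Nc2ncnc3c2OCCN3)cc1` gives 3070 nM, and compound 1 `O=C(Nc1ccc(Nc2ncnc3c2OCCN3)cc1)Nc1ccc(Cl)c(C(F)(F)F)c1` gives 177 nM. Compound 4 `O=C(Nc1ccc(Nc2ncnc3c2OCCN3)cc1)Nc1ccc(C(F)(F)F)cc1` differs from compound 3 by trifluoromethyl in place of bromo on an aromatic carbon. Going by the values given here, two measured steps bear on this change. Taking the trifluoromethyl out of compound 1 gave a 17-fold higher number from compound 1 to compound 2 (1.24 log units; beyond the scatter), whereas a 1.4-fold lower number from compound 2 to compound 3 (0.14 log units; within the scatter) stayed within the scatter, so the trifluoromethyl, not the halogen, accounts for the spread seen. Because compound 1 gives 177 nM while still carrying its chloro, whereas in compound 4 the trifluoromethyl enters in place of the bromo, a smaller gain is expected, a 3.2-fold lower number from compound 3 to compound 4 (0.50 log units; beyond the scatter). Compound 4 is accordingly estimated at 700 nM, with a range from 250 nM to 2000 nM.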

Compound 4, half-maximal inhibitory concentration: 306 nM
The estimate for compound 4 lay 2.3-fold (0.36 log units) above the measured number; the range from low to high includes it.
By their numbers in this assay, from the lowest: compounds 1 and 4 (each within the scatter of the next); then compounds 3 and 2 (each within the scatter of the next).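

In this assay, trifluoromethyl at this position, para to a large group, stands clear of both halogens, with a 7.3-fold lower number from compound 3 to compound 4 (0.86 log units; beyond the scatter) and a 10-fold lower number from compound 2 to compound 4 (1.00 log units; beyond the scatter) as the two steps to it. The earlier drop on removing trifluoromethyl came from a compound that also carried chloro, whereas compound 4 shows the lower number with trifluoromethyl alone on that ring. Nothing available explains this gain. As far as these compounds go, whether a nitrile, a methoxy group, an amine or a carboxylic acid at this position would match trifluoromethyl remains open. So does how far a longer chain would be tolerated there.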